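A few compounds are considered here, and "the series" means these few. Any claim that something is new, unique, unknown or untested is made for them only; others in the source may bear on it.

For the measured compounds named here, compound 1, `CCC1(CCCCN2CCN(c3ccc(F)cc3)CC2)C(=O)Nc2ccccc21`, is the only compound of the three with a single number in a functional assay on the whole organism (strain Wistar) with Rattus norvegicus as the target, with a stated time of 5 min; on this read-out higher numbers stand for an effect only at larger amounts of compound and lower numbers for an effect already at smaller amounts: compound 1 gives 10 mg/kg. Compound 3, `CCC1(CCCCN2CCN(c3ccc(F)cc3)CC2)C(=O)Nc2ccc(F)cc21`, carries fluoro in place of hydrogen on an aromatic carbon of the shared core. In this assay compound 3 gives only a limit of the assay, > 20 mg/kg. That step is an at least 2.0-fold higher number from compound 1 to compound 3 (0.30 log units; that floor lies within the scatter), and the floor of it rests on (the limit of > 20 mg/kg in this assay, at which 1 of the 3 values shown sits). Compound 2, `CCC1(CCCCN2CCN(c3ccc(Cl)cc3)CC2)C(=O)Nc2cc(F)c(Cl)cc21`, has no result in this assay: compound 2 stands at "not determined" (no result reported).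

Compound 4, `CCC1(CCCCN2CCN(c3cccc(OC)c3)CC2)C(=O)Nc2ccccc21`, differs from compound 1 at another place, (3-methoxyphenyl in place of 4-fluorophenyl on an amine nitrogen in a ring). Going by the values given here, the one measured step concerns the aromatic ring of the core, not the aryl on the amine nitrogen in a ring, so no measured step bears on this change. Compound 4 is therefore expected to stay close to compound 1, with no change at the digits printed from compound 1 to compound 4 (within the scatter) as the expected step, within the scatter. For compound 4 in this assay the estimate is 10 mg/kg, expected between 5 mg/kg and 20 mg/kg.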

Compound 4, minimum effective dose: > 20 mg/kg
Compound 4 gave a limit, no number; the forecaster's own chance of this, stated with the estimate: 30%; at least 2.0-fold (0.30 log units) between middle value and limit.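

For the compounds shown here, the aryl group on the amine nitrogen in a ring had no measured step until now, and replacing 4-fluorophenyl with 3-methoxyphenyl there gives an at least 2.0-fold higher number from compound 1 to compound 4 (0.30 log units; that floor lies within the scatter) in this assay. A change at this place, away from the aromatic ring of the core, therefore also ends in a limit rather than a number, just as the fluoro change in compound 3 did. The two changes cannot be ranked against each other, and the true size of either step cannot be read, since the floor of each lies within the scatter and both compounds rest on the same limit: the limit of > 20 mg/kg in this assay, at which 2 of the 4 values shown sit.

The compounds shown leave open whether the step follows from the methoxy group, from its place on the phenyl ring, or from the loss of fluoro. An unsubstituted phenyl or a pyridine ring on that nitrogen would help to separate these readings.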